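Methyl-to-hydrogen change in a nitric oxide donor series

The compounds below may be only part of what the source reports. "The series", "measured", "known", "first", "only" and "open" are said of these compounds alone.

Measured compounds:
compound 1 `CC(C)=CCC/C(C)=C/CC/C(C)=C/CSc1ccccc1C(=O)N[C@@H](C)C(=O)OCC#CCOc1no[n+]([O-])c1S(=O)(=O)c1ccccc1` gives 1010 nM in a functional assay on MDA-MB-231 cells (Homo sapiens) for cytotoxicity, read by MTT assay, with a stated time of 48 h; on this read-out lower numbers stand for stronger inhibition and higher numbers for weaker inhibition
compound 2 `CC(C)=CCC/C(C)=C/CC/C(C)=C/CSc1ccccc1C(=O)N[C@@H](C)C(=O)OCCCCOc1no[n+]([O-])c1S(=O)(=O)c1ccccc1` gives > 50000 nM in this assay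
compound 3 `CC(C)=CCC/C(C)=C/CC/C(C)=C/CSc1ccccc1C(=O)NCC(=O)OCCCCOc1no[n+]([O-])c1S(=O)(=O)c1ccccc1` gives 9990 nM in this assay

Compound 2 is reported only as a limit of the assay, not a number; its value sits at the limit of > 50000 nM in this assay, at which 1 of the 3 values shown sits. Compound 2 and compound 3 differ by a single change, (hydrogen in place of methyl on a saturated chain carbon bound to an amide-type nitrogen and a carbonyl carbon), and that change gave an at least 5.0-fold lower number from compound 2 to compound 3 (0.69 log units; beyond the scatter). Compound 1 and compound 2 differ in their cores, and that difference is not broken down here; their values simply show compound 1 giving a number where compound 2 gives only a limit.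

Compound 4 `CC(C)=CCC/C(C)=C/CC/C(C)=C/CSc1ccccc1C(=O)NCC(=O)OCC#CCOc1no[n+]([O-])c1S(=O)(=O)c1ccccc1` has not yet been measured. It is made from compound 1 by the same change, at the same place: hydrogen in place of methyl on a saturated chain carbon bound to an amide-type nitrogen and a carbonyl carbon. For compound 4 the expected step is a 3.4-fold lower number from compound 1 to compound 4 (0.53 log units; beyond the scatter), resting on the step of an at least 5.0-fold lower number from compound 2 to compound 3 (0.69 log units; beyond the scatter), though that step starts from a limit and so its true size is uncertain. For compound 4 the estimate is 300 nM, expected to fall between 80 nM and 1500 nM.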

Compound 4, half-maximal inhibitory concentration: 7230 nM
Compound 4: the middle estimate sits 24-fold (1.38 log units) below what was measured; measured number above the stated range.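

In this assay, putting hydrogen in place of methyl on the saturated chain carbon bound to an amide-type nitrogen and a carbonyl carbon gave a 7.2-fold higher number from compound 1 to compound 4 (0.85 log units; beyond the scatter), which means weaker inhibition on the core of compound 1. This change therefore did not carry from one core to the other, since its direction reversed between them: the same change on two cores in this assay, an at least 5.0-fold lower number (0.69 log units; beyond the scatter) from compound 2 to compound 3 and a 7.2-fold higher number (0.85 log units; beyond the scatter) from compound 1 to compound 4, at least 35-fold (1.55 log units) apart, beyond the scatter of two such steps

Compound 2 is recorded only as a limit, > 50000 nM, so the earlier step has no exact size, and a single pair on each core shows that the core matters without showing how or why.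

The compounds shown leave open how a longer chain, such as ethyl, would behave at this same carbon on either core. They also leave open which of the two opposite outcomes, if either, would appear on a third core.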